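Sulfonamides on a shared core: the step to compound 4

A few compounds are considered here, and "the series" means these few. Any claim that something is new, unique, unknown or untested is made for them only; others in the source may bear on it.

Compound 1, `O=S(=O)(Nc1ccc2oc(-c3ccccc3)nc2c1)c1ccc(Cl)c(Cl)c1`: in an assay on cells for inhibition of HSP60/HSP10 (Homo sapiens), with a stated time of 60 min (a higher number here means a weaker inhibitor, a lower number a stronger inhibitor), compound 1 gives > 100000 nM, which is a limit of the assay.
Compound 2, `Cc1ccccc1S(=O)(=O)Nc1ccc2oc(-c3ccccc3)nc2c1`: compound 2 gives > 100000 nM, a limit of the assay.
Compound 3, `Cc1cccc(S(=O)(=O)Nc2ccc3oc(-c4ccccc4)nc3c2)c1`: compound 3 gives > 100000 nM, a limit of the assay.

Compound 3 stands at the limit of this assay, and its two companions show only the same limit, so no order among the three can be read from the numbers. The measured steps a step that the two limits leave unreadable from compound 1 to compound 2, a step that the two limits leave unreadable from compound 1 to compound 3 and a step that the two limits leave unreadable from compound 2 to compound 3 are all unreadable for this reason: the limit of > 100000 nM in this assay, at which 3 of the 3 values shown sit.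

Compound 4, `O=S(=O)(Nc1ccc2oc(-c3ccccc3)nc2c1)c1cccs1`, differs from compound 3 in one place: thiophen-2-yl in place of 3-methylphenyl on a sulfonyl sulfur.

All three measured exchanges change the group on the sulfonyl sulfur, and none yielded a readable step, so they bear on the new exchange only by showing that earlier variation at this position left every compound at the limit. Going by the values given here, no measured step points to a change beyond the scatter in this assay, in either direction. The step expected in this assay is a step that the limit leaves unreadable from compound 3 to compound 4. Compound 4 is therefore estimated at 150000 nM, within a range from 50000 nM to 500000 nM, and is most likely to be reported only as a limit.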

Compound 4, half-maximal inhibitory concentration: 90000 nM
Beside the measured number, compound 4's estimate is 1.7-fold (0.22 log units) above it; the measured number falls inside the stated range.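

In this assay, going by these compounds alone, thiophen-2-yl on the sulfonyl sulfur gives the only number in this set that is not a limit, so this position can hold a group that brings a compound inside the range of the read-out. The comparison with the three phenyl-bearing sulfonamides yields only floors, namely an at least 1.1-fold lower number from compound 3 to compound 4 (0.04 log units; that floor lies within the scatter) for the exchange of 3-methylphenyl, an at least 1.1-fold lower number from compound 2 to compound 4 (0.04 log units; that floor lies within the scatter) for the exchange of 2-methylphenyl and an at least 1.1-fold lower number from compound 1 to compound 4 (0.04 log units; that floor lies within the scatter) for the exchange of 3,4-dichlorophenyl, and none of them establishes a real gain for compound 4. The true size of each step stays hidden and the floors are identical, so the exchange cannot be ranked against any of the three groups it replaces, for the following reason: the limit of > 100000 nM in this assay, at which 3 of the 4 values shown sit.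

Still open, as far as these compounds go, is how far compounds 1, 2 and 3 actually lie from compound 4, and whether thiophen-2-yl itself matters or any group other than those three phenyl groups would do the same. Also open, from the compounds shown here alone, is whether an amine or a carboxylic acid on the sulfonyl-bound ring would move the number clearly beyond the scatter.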